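Two Ring Stereocentres Await a Permeability Reading

The source may report more compounds than this note shows. Statements on the series, on what has been measured and on what is new or still open speak of the compounds shown alone.

In an ADME assay on MDCKII-LE cells (Canis lupus familiaris) for permeability (on this read-out higher numbers stand for higher permeability and lower numbers for lower permeability), compound 1 (`NC(=O)[C@@H](CCC(F)(F)F)N(CC12CC(c3ncon3)(C1)C2)S(=O)(=O)c1ccc(Cl)cc1`) gives 19.3 10^-6 cm/s and compound 2 (`C[C@]1(C#N)C[C@H](CN([C@H](CCC(F)(F)F)C(N)=O)S(=O)(=O)c2ccc(Cl)cc2)C1`) gives 21.8 10^-6 cm/s. The step of a 1.1-fold higher number from compound 1 to compound 2 (0.05 log units; within the scatter) lies within the scatter, so these two stand level. Compound 3 (`C[C@]1(C#N)C[C@@H](CN([C@H](CCC(F)(F)F)C(N)=O)S(=O)(=O)c2ccc(Cl)cc2)C1`) departs from compound 2 as follows: the two compounds have the same atoms and bonds and differ only in configuration as drawn: 2 of 3 stereo elements differ; a stereocentre at a saturated ring carbon is drawn R in compound 2 and S in compound 3; a stereocentre at a saturated ring carbon is drawn r in compound 2 and s in compound 3. Going by the values given here, no measured step tests configuration alone. The only one available, a 1.1-fold higher number from compound 1 to compound 2 (0.05 log units; within the scatter), replaced a whole group and stayed within the scatter, so no shift beyond the scatter is expected in this assay. The expected step is a 1.0-fold lower number from compound 2 to compound 3 (0.02 log units; within the scatter). For compound 3 the estimated value is 21 10^-6 cm/s, with an expected range of 12 10^-6 cm/s to 35 10^-6 cm/s.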

Compound 3, apparent permeability: 25.7 10^-6 cm/s
Compound 3: middle estimate off by 1.2-fold (0.09 log units), on the low side; measured number inside the range.
By their numbers in this assay, from the lowest: compounds 1, 2 and 3 (each within the scatter of the next).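

In this assay, going by these compounds alone, the step of a 1.2-fold higher number from compound 2 to compound 3 (0.07 log units; within the scatter) is the first to test configuration alone, and drawing the two ring stereocentres the other way leaves the number within the scatter. The step of a 1.3-fold higher number from compound 1 to compound 3 (0.12 log units; within the scatter) also stays within the scatter, so neither ring configuration separates from the group in compound 1. The comparison of configuration rests on one fact: the fact that compounds 2 and 3 differ only in the configuration as drawn

As far as these compounds go, whether configuration at these ring carbons would still make so little difference with a carboxylic acid or an amine in place of the nitrile stays open. From the compounds shown here alone, the third stereo element, the same in compound 2 and compound 3, also remains untested.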